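Swapping the aryl amine in a chalcone-thiazole pair

This account rests on a few compounds, and the source may have more. Where it says the series, first, only, none or still open, it means among the compounds named here.

Measured compounds:
compound 1 `Cc1cccc(Nc2nc(C)c(C(=O)/C=C/c3ccccc3Cl)s2)c1`: 22200 nM
compound 2 `COc1cc(/C=C/C(=O)c2sc(Nc3ccc(Cl)c(Cl)c3)nc2C)cc(OC)c1OC`: 19300 nM

Both were tested in a functional assay on PC-3 cells (Homo sapiens) for cytotoxicity, read by MTT assay; a higher number here means a weaker inhibitor, a lower number a stronger inhibitor. Compound 1 gives 22200 nM and compound 2 gives 19300 nM there; the gap between them lies within the scatter, so the two cannot be told apart on these numbers. Both are weak inhibitors of the cells' growth.

Compound 3 `COc1cc(/C=C/C(=O)c2sc(Nc3ccccc3C)nc2C)cc(OC)c1OC` has not yet been measured. It differs from compound 2 in one place: 2-methylphenyl in place of 3,4-dichlorophenyl on a nitrogen on an aromatic ring. The rest of the shared core, including the carbonyl-linked trimethoxyphenyl side, stays as in compound 2. Among the measured compounds shown here, no pair of measured compounds differing only in this spot exists, so there is nothing to read a direction from. The two measured compounds, with different groups on that nitrogen, both sit at weak inhibition, and compound 3 is expected to stay there too; the expected step from compound 2 is a 1.1-fold higher number from compound 2 to compound 3 (0.06 log units; within the scatter), none beyond the scatter. Compound 3 is estimated at 22000 nM, with a likely range from 9000 nM to 55000 nM.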

Compound 3, half-maximal inhibitory concentration: > 25000 nM
Compound 3 gave a limit, no number; the forecaster's own chance of this, stated with the estimate: 15%; middle value at least 1.1-fold (0.05 log units) away from the limit.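

Among the compounds shown here, this is the first direct reading at this position, the aryl group on the nitrogen: 2-methylphenyl in place of 3,4-dichlorophenyl gives an at least 1.2-fold higher number from compound 2 to compound 3 (0.11 log units; that floor lies within the scatter). In this assay, compound 3 gives > 25000 nM, which is a limit of the assay and not a number. The change therefore brought no gain in strength, but its true size stays unknown, and it may be small or large, because the reading stops at a limit: the limit of > 25000 nM in this assay, at which 1 of the 3 values shown sits.

The change also swaps both chlorines for one methyl at once, so these compounds cannot show which part of the swap matters. Nor do they show whether a plain phenyl, or a phenyl carrying an amine or a carboxylic acid, on that nitrogen would move the number in either direction.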